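A few compounds are considered here, and "the series" means these few. Any claim that something is new, unique, unknown or untested is made for them only; others in the source may bear on it.

Measured so far:
compound 1 `N#Cc1c(-c2ccc(Oc3ccccc3)cc2)ccn2c(CC(F)(F)F)cnc12` — 186 nM
compound 2 `CCc1cnc2c(C#N)c(N3CCN(c4ncccn4)CC3)ccn12` — > 3160 nM
compound 3 `Cc1cc(C)nc(N2CCN(c3ccn4c(CC(F)(F)F)cnc4c3C#N)CC2)n1` — 447 nM

In a functional assay on CHO cells with metabotropic glutamate receptor 2 (Homo sapiens) as the target, read by GTPgammaS binding (on this read-out lower numbers stand for an effect already at smaller amounts and higher numbers for an effect only at larger amounts of compound), compound 1 gives 186 nM, the lowest of the two numbers obtained. Compound 3 gives 447 nM, a higher number, and the gap between these two lies beyond the usual scatter. For compound 2 the result is a limit of the assay and not a number: > 3160 nM. The one limit on record is the limit of > 3160 nM in this assay, at which 1 of the 3 values shown sits.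

The open question is compound 4 `CC(C)(C)c1ccc(-c2ccn3c(CC(F)(F)F)cnc3c2C#N)cc1`, not yet measured in this assay. It differs from compound 1 in one place: tert-butyl in place of phenoxy on an aromatic carbon. Within the data shown here, no pair of measured compounds in the set shows this kind of exchange, so the size of the step has to be guessed from the structures alone. A moderate rise in the number is expected, since the phenoxy is replaced by a smaller group that keeps no hydrogen-bond acceptor, though a result within the scatter would not be surprising either.

For compound 4 the estimate in this assay is 350 nM, with a range from 90 nM to 1400 nM. This estimate means a step of a 1.9-fold higher number from compound 1 to compound 4 (0.27 log units; within the scatter).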

Compound 4, half-maximal effective concentration: 447 nM
Beside the measured number, compound 4's estimate is 1.3-fold (0.11 log units) below it; the range from low to high includes it.
By their numbers in this assay, from the lowest: compound 1; then compounds 3 and 4 (each within the scatter of the next). At a limit, above all of these: compound 2.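

Among these compounds, until now no measured pair isolated a single change on the group attached to the core, so this step is the first reading for this place, an aromatic carbon of a six-membered aromatic ring of carbon only, para to a large group. In this assay, tert-butyl in place of phenoxy gives a 2.4-fold higher number from compound 1 to compound 4 (0.38 log units; beyond the scatter), a modest change for a swap that removes 7 heavy atoms, a ring and a hydrogen-bond acceptor and brings in 4 heavy atoms with neither a ring nor an acceptor. A measurable number therefore survives at this place without the second aromatic ring or the oxygen, although the step cannot divide its size between the two, and nothing on record accounts for the step.

As far as these compounds go, whether the loss follows the oxygen, the ring or the size of the group stays open, and a benzyl or a phenyl group at the same place would help to separate these. How a carboxylic acid or an amine at this place would read in this assay also remains unknown from the compounds shown.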